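From Methyloxazole to Pyrazine on the Aniline Ring

The source may report more compounds than this note shows. Statements on the series, on what has been measured and on what is new or still open speak of the compounds shown alone.

Compound 1 `Cc1nc(-c2ccccc2NCC2=NCCN2)cs1` and compound 2 `Cc1cc(-c2ccccc2NCC2=NCCN2)on1` share one core and differ only in the attached ring. In a functional assay for activation of Alpha-1D adrenergic receptor (Homo sapiens) (on this read-out higher numbers stand for an effect only at larger amounts of compound and lower numbers for an effect already at smaller amounts), compound 1 gives only a limit, < 5020 nM. In this assay compound 2 likewise gives only a limit, < 100000 nM. The step that the two limits leave unreadable from compound 1 to compound 2 stays unreadable because the limit of < 100000 nM in this assay, at which 1 of the 2 values shown sits, and the limit of < 5020 nM in this assay, at which 1 of the 2 values shown sits, cap both values. Compound 3 `c1ccc(-c2cnccn2)c(NCC2=NCCN2)c1` carries pyrazin-2-yl in place of 3-methyl-1,2-oxazol-5-yl on an aromatic carbon. Going by the values given here, no measured step bears on this change, so no direction beyond the scatter is claimed. Compound 3 is estimated at 5000 nM, expected between 500 nM and 50000 nM. The expected step that the limit leaves unreadable from compound 2 to compound 3 is set near no change.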

Compound 3, half-maximal effective concentration: 182 nM
Compound 3: middle estimate off by 27-fold (1.44 log units), on the high side; the whole stated range lies above it.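

Neither step to compound 3, from compound 1 or from compound 2, can be read in this assay, as both of those compounds give only limits. The compounds shown leave open how pyrazin-2-yl truly ranks against 3-methyl-1,2-oxazol-5-yl or 2-methyl-1,3-thiazol-4-yl.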